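The source may report more compounds than this note shows. Statements on the series, on what has been measured and on what is new or still open speak of the compounds shown alone.

Measured compounds:
- compound 1, `Cc1ccc(S(=O)(=O)/N=C(/CCNC2=CC(=O)c3ccccc3C2=O)Nc2cccc(C)c2)cc1`: 10200 nM
- compound 2, `Cc1ccc(S(=O)(=O)/N=C(/CCNC2=CC(=O)c3ccccc3C2=O)Nc2ccc(Cl)cc2Cl)cc1`: 18600 nM
- compound 3, `Cc1ccc(S(=O)(=O)/N=C(/CCNC2=CC(=O)c3ccccc3C2=O)Nc2cc(F)c(F)c(F)c2)cc1`: 12600 nM

Three compounds share one core and differ only in the aromatic group carried on an amine nitrogen. In a functional assay on DU-145 cells (Homo sapiens) for cytotoxicity, read by MTT assay, with a stated time of 48 h (a lower number here means a stronger inhibitor, a higher number a weaker inhibitor), compound 1 gives the lowest of the three numbers, but the gaps to the other two are small: the step of a 1.8-fold higher number from compound 1 to compound 2 (0.26 log units; within the scatter) and the step of a 1.2-fold higher number from compound 1 to compound 3 (0.09 log units; within the scatter) both lie within the scatter, as does the step of a 1.5-fold lower number from compound 2 to compound 3 (0.17 log units; within the scatter) between compounds 2 and 3. So the three measured compounds cannot be told apart on these numbers.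

Compound 4, `Cc1ccc(S(=O)(=O)/N=C(\N)CCNC2=CC(=O)c3ccccc3C2=O)cc1`, has not yet been measured in this assay. It differs from compound 1 as follows: hydrogen in place of 3-methylphenyl on an amine nitrogen. The measured steps all swap one aromatic group for another on that nitrogen and none of them moved the number beyond the scatter. For the measured compounds named here, the change to compound 4 is of a different kind, since it removes the aromatic group altogether and leaves only amino there, and no measured pair shows what that does. The most that can be drawn from the data is that the nitrogen substituent has so far mattered little, so the expectation is a step of a 1.6-fold higher number from compound 1 to compound 4 (0.20 log units; within the scatter) of modest size, more likely toward a higher number, with wide uncertainty. For compound 4 the estimate is 16000 nM, expected to fall between 6000 nM and 45000 nM.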

Compound 4, half-maximal inhibitory concentration: 30900 nM
Compound 4: the middle estimate sits 1.9-fold (0.29 log units) below what was measured, and the stated range covers the measured number.
By their numbers in this assay, from the lowest: compounds 1, 3, 2 and 4 (each within the scatter of the next, the first and the last beyond it).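

In this assay, taking the aromatic group off the amine nitrogen and leaving plain amino does what no swap of one aromatic group for another did: it moves the number beyond the scatter, with a 3.0-fold higher number from compound 1 to compound 4 (0.48 log units; beyond the scatter) and a 2.5-fold higher number from compound 3 to compound 4 (0.39 log units; beyond the scatter). Compound 2 goes against this pattern, since a 1.7-fold higher number from compound 2 to compound 4 (0.22 log units; within the scatter), so the loss shows against two of the three aromatic groups only. An aromatic group on this nitrogen therefore appears to count for something in compound 1 and compound 3, even though the choice among the three aromatic groups does not show in the numbers, and nothing available explains why the step is as large as it is.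

The compounds shown carry only hydrogen or a substituted phenyl group at this place, so it stays open whether the aromatic ring itself matters or whether any carbon group would serve as well. A small methyl group, a non-aromatic cyclohexyl ring or a benzyl group, with one extra carbon before the ring, would help to separate these possibilities.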